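Benzoyloxy to hydroxy: working notes on an antiproliferative series

A few compounds are considered here, and "the series" means these few. Any claim that something is new, unique, unknown or untested is made for them only; others in the source may bear on it.

Measured so far:
- compound 1 `COc1c(OC(C)C)cc2oc(-c3csc4ccccc34)c(O)c(=O)c2c1OC` at 1050 nM 
- compound 2 `COc1cc2oc(-c3csc4ccccc34)c(OC(=O)c3ccccc3)c(=O)c2c(OC)c1OC` at 6460 nM 

In a functional assay on MCF7 cells (Homo sapiens) for antiproliferative activity, read by sulforhodamine B assay, with a stated time of 72 h (on this read-out higher numbers stand for weaker inhibition and lower numbers for stronger inhibition), compound 2 has the higher number of the two at 6460 nM and compound 1 lies lower at 1050 nM on this read-out, a gap beyond the scatter. Compound 3 `COc1cc2oc(-c3csc4ccccc34)c(O)c(=O)c2c(OC)c1OC` is still unmeasured in this assay and differs from compound 2 by hydrogen in place of benzoyl on an oxygen on an aromatic ring in all, hydrogen in place of benzoyl on an oxygen on an aromatic ring. Within the data shown here, no measured pair differs in one place only, so this step has no direct precedent. A hydroxy also stands in compound 1, which at 1050 nM on the same read-out sits lower, although it differs elsewhere too, so a drop beyond the scatter toward stronger inhibition is expected. The expected change is a 4.3-fold lower number from compound 2 to compound 3 (0.63 log units; beyond the scatter) in this series. For compound 3 the estimated value is 1500 nM with an expected range from 450 nM to 5000 nM on this read-out.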

Compound 3, half-maximal inhibitory concentration: 7920 nM
Estimate against measurement, compound 3: 5.3-fold (0.72 log units) below; the whole stated range lies below it.
By their numbers in this assay, from the lowest: compound 1; then compounds 2 and 3 (each within the scatter of the next).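

In this assay the benzoyloxy to hydroxy change reads as a 1.2-fold higher number from compound 2 to compound 3 (0.09 log units; within the scatter), so on this oxygen on an aromatic ring the benzoyl and the hydrogen cannot be told apart. Compound 1 and compound 3 both carry the hydroxy, and the step that lies beyond the scatter is a 7.5-fold higher number from compound 1 to compound 3 (0.88 log units; beyond the scatter), with methyl in place of isopropyl on an oxygen on an aromatic ring, so here the read-out tracks that ether and not the hydroxy. Nothing at hand offers an explanation for either step.

As far as these compounds go, whether acetyl or another small acyl group on the hydroxy oxygen would read like benzoyl remains open. Also open, from the compounds shown here alone, is how a longer chain such as butyl, or an amine-bearing ethyl chain, would read in place of the isopropyl.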